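The source may report more compounds than this note shows. Statements on the series, on what has been measured and on what is new or still open speak of the compounds shown alone.

Early solubility readings give a first sense of how much of a compound can stay in solution, and here there are only two to work from. In a physicochemical assay for solubility (on this read-out lower numbers stand for lower solubility and higher numbers for higher solubility), compound 1 `CCNC(=O)Nc1ccc(-c2nc3cccc(C(N)=O)c3s2)cn1` gives < 1000 nM, which is a limit of the assay and not a number. In this assay, within the data shown here, compound 2 `CCNC(=O)Nc1cc(-c2nc(C(F)(F)F)cs2)c(-c2cncc(C(N)=O)c2)cn1` gives 26000 nM, the only true number so far. The two compounds differ in more than one place, so their values do not show what any single change does.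

Compound 3 `CCNC(=O)Nc1cc(-c2nc(C(F)(F)F)cs2)c(-c2cncc(-c3c(C)noc3C)c2)cn1` keeps the frame of compound 2 but carries 3,5-dimethyl-1,2-oxazol-4-yl in place of carbamoyl on an aromatic carbon. Among the measured compounds shown here, no measured pair shows this swap, so the expectation rests on the structural change alone, and it is an uncertain one. A clear fall beyond the usual scatter is expected, an estimated step of a 10-fold lower number from compound 2 to compound 3 (1.02 log units; beyond the scatter). The estimate for compound 3 is 2500 nM, with an expected range from 700 nM to 12000 nM.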

Compound 3, solubility: 6000 nM
Estimate against measurement, compound 3: 2.4-fold (0.38 log units) below; the range from low to high includes it.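

Among these compounds, this is the first comparison here that differs in one place only. Putting 3,5-dimethyl-1,2-oxazol-4-yl in place of carbamoyl on this aromatic carbon, two atoms from the ring nitrogen, gives a 4.3-fold lower number from compound 2 to compound 3 (0.64 log units; beyond the scatter) in this assay, a modest step that still lies beyond the usual scatter. The position therefore accepts a group of 7 heavy atoms with one five-membered aromatic ring and 0 hydrogen-bond donors in place of one of 3 heavy atoms with 1 hydrogen-bond donor, and the read-out moves by that measured amount. The reading of compound 3 remains a true number, and only compound 1 sits at a limit of the assay: the limit of < 1000 nM in this assay, at which 1 of the 3 values shown sits.

This one swap changes the size, the ring and the hydrogen-bond count all at once, so it cannot show which of these differences accounts for the step. Also open, as far as these compounds go, is where a primary amine or a carboxylic acid on the same aromatic carbon would fall in this assay, and whether 3,5-dimethyl-1,2-oxazol-4-yl would give a similar step on the core of compound 1.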